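Amino in Place of Ethoxy on the Benzamide of Compound 3

The source may hold more compounds than are shown below. What is called first, only, known or untested is meant among the compounds shown, and "the series" means these compounds.

Compound 3 `CCOc1ccc(C(=O)Nc2cccc(NC(=O)COc3ccc4c(=O)ccoc4c3)c2)cc1` gives 17 nM in an assay on isolated protein for inhibition of Rho-associated protein kinase 1 (Homo sapiens), read by scintillation counting, radiometric assay and 33P incorporation, with a stated time of 40 min, in the presence of a further agent that is not named here (on this read-out lower numbers stand for stronger inhibition and higher numbers for weaker inhibition), the lowest of the three numbers recorded here. In this assay compound 2 `COc1ccc(OCC(=O)Nc2cccc(NC(=O)c3ccc(N(C)C)cc3)c2)cc1F` gives 1820 nM and compound 1 `COc1cc(OCC(=O)Nc2cccc(NC(=O)c3ccc(N(C)C)cc3)c2)ccc1C=O` gives 3740 nM, both far above compound 3. For the measured compounds named here, the only measured step, a 2.1-fold lower number from compound 1 to compound 2 (0.31 log units; beyond the scatter), alters the group on an oxygen on a saturated carbon, a different place from the one changed in compound 4 `Nc1ccc(C(=O)Nc2cccc(NC(=O)COc3ccc4c(=O)ccoc4c3)c2)cc1`: amino in place of ethoxy on an aromatic carbon. Going by the values given here, no measured step therefore bears on this change, and nothing in the data points to a large shift either way. A small step is expected, a 1.8-fold higher number from compound 3 to compound 4 (0.25 log units; within the scatter), toward a somewhat higher number. Compound 4 is accordingly estimated at 30 nM, with a range from 8 nM to 120 nM.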

Compound 4, half-maximal inhibitory concentration: 802 nM
For compound 4 the middle estimate is 27-fold (1.43 log units) below the measured one, and the stated range ends below it.
By their numbers in this assay, from the lowest: compound 3; then compound 4; then compound 2; then compound 1.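

This position, para to a large group, is far from indifferent in this assay: amino in place of ethoxy gives a 47-fold higher number from compound 3 to compound 4 (1.67 log units; beyond the scatter). For the compounds shown here, on this core, then, the ethoxy group cannot be exchanged for amino without a large change in the number, something the earlier compounds, which differ elsewhere, could not show. From the compounds shown here alone, whether a methoxy group, a propoxy chain or a methylamino group at this place would stay close to compound 3 or to compound 4 remains open. Nothing measured here accounts for the size of this step.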